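This account rests on a few compounds, and the source may have more. Where it says the series, first, only, none or still open, it means among the compounds named here.

Compound 1 `COc1ccc(/C=C\c2cc(OC)c(OC)c(OC)c2)cc1OCc1ccc(CNC(C)(C)C(=O)O)cc1` was examined in an ADME assay on NCM460 cells (Homo sapiens) for cytotoxicity, read by CCK-8 assay, with a stated time of 48 h; a lower number here means a stronger inhibitor, a higher number a weaker inhibitor. In this assay compound 1 gives only a limit, > 50000 nM. Compound 2 `COc1ccc(/C=C\c2cc(OC)c(OC)c(OC)c2)cc1OCc1ccc(CO)cc1` likewise gives only a limit, > 50000 nM. Compound 3 `COc1ccc(/C=C\c2cc(OC)c(OC)c(OC)c2)cc1OCc1ccc(CN2CC[C@@H](C(=O)O)C2)cc1` also gives only a limit, > 50000 nM. The steps among these three compounds are a step that the two limits leave unreadable from compound 1 to compound 2, a step that the two limits leave unreadable from compound 1 to compound 3 and a step that the two limits leave unreadable from compound 2 to compound 3; none of them can be sized because of the limit of > 50000 nM in this assay, at which 3 of the 3 values shown sit. Compound 1 therefore stands nowhere in particular among the numbers shown: it shares the same limit with compound 2 and compound 3.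

Compound 4 `COc1ccc(/C=C\c2cc(OC)c(OC)c(OC)c2)cc1OCc1ccc(CN2CC[C@@H](O)C2)cc1` differs from compound 1 by 3-hydroxypyrrolidin-1-yl in place of (1-carboxy-1-methylethyl)amino on a saturated chain carbon bound to an aromatic carbon. The change from compound 1 to compound 3, which also brings a pyrrolidin-1-yl group onto that chain carbon, left the value at the limit, and the change to compound 2 did the same. Among the measured compounds shown here, no measured step on this series is readable, so no step of any size in either direction can be expected beyond the scatter in this assay. Compound 4 is accordingly expected to give 60000 nM, with a range from 25000 nM to 150000 nM. The step expected from compound 1 to compound 4 is a step that the limit leaves unreadable from compound 1 to compound 4.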

Compound 4, half-maximal inhibitory concentration: 53000 nM
For compound 4 the middle estimate is 1.1-fold (0.05 log units) above the measured one; measured number inside the range.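

The steps to compound 4 from compound 1, compound 2 and compound 3 cannot be read in this assay, because each of those three compounds gives only a limit: the limit of > 50000 nM in this assay, at which 3 of the 4 values shown sit.

The compounds shown leave open how far any of these three lies from compound 4, including whether hydroxy in place of carboxy on a saturated ring carbon changes the value at all.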